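Cytotoxicity in Fibroblasts: Swapping an Aryl Group on the Triazole

The source may report more compounds than this note shows. Statements on the series, on what has been measured and on what is new or still open speak of the compounds shown alone.

Measured compounds:
compound 1 `O=C1O[C@H]([C@@H](O)Cn2cc(-c3cc(C(F)(F)F)cc(C(F)(F)F)c3)nn2)C(OCc2ccccc2)=C1OCc1ccccc1`, 80700 nM
compound 2 `O=C1O/C(=C\Cn2cc(-c3cc(F)cc(F)c3)nn2)C(OCc2ccccc2)=C1OCc1ccccc1`, > 100000 nM
compound 3 `O=C1O[C@H]([C@@H](O)Cn2cc(CNS(=O)(=O)c3ccc(F)cc3)nn2)C(OCc2ccccc2)=C1OCc1ccccc1`, 30 nM

In an ADME assay on HFF cells (Homo sapiens) for cytotoxicity, read by MTT assay, with a stated time of 72 h (on this read-out higher numbers stand for weaker inhibition and lower numbers for stronger inhibition), compound 1 gives 80700 nM and compound 3 gives 30 nM. For compound 2 the result is only a limit of the assay, > 100000 nM. Compound 2 therefore sits at the limit of > 100000 nM in this assay, at which 1 of the 3 values shown sits, the weakest point the assay reports.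

Compound 4 `O=C1O/C(=C\Cn2cc(-c3cccc(O)c3)nn2)C(OCc2ccccc2)=C1OCc1ccccc1` differs from compound 2 in one place: 3-hydroxyphenyl in place of 3,5-difluorophenyl on an aromatic carbon. Within the data shown here, no measured pair shows the effect of such a change. Since compound 2 already sits at the limit (the limit of > 100000 nM in this assay, at which 1 of the 3 values shown sits), the expected step from compound 2 to compound 4 is an at least 1.1-fold lower number from compound 2 to compound 4 (0.04 log units; that floor lies within the scatter), none beyond the scatter. Compound 4 is estimated at 90000 nM, in the range 30000 nM to 300000 nM.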

Compound 4, half-maximal inhibitory concentration: 42600 nM
Compound 4: middle estimate off by 2.1-fold (0.32 log units), on the high side, and the stated range covers the measured number.
By their numbers in this assay, from the lowest: compound 3; then compounds 4 and 1 (each within the scatter of the next). At a limit, above all of these: compound 2.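

Replacing 3,5-difluorophenyl with 3-hydroxyphenyl on the five-membered aromatic ring gives a real number in this assay, and the result is an at least 2.3-fold lower number from compound 2 to compound 4 (0.37 log units; beyond the scatter). Among these compounds, this shows that the read-out responds to a change of aryl group at this position, which no earlier pair could show. The true size of the step stays unknown because compound 2 stands at a limit of the assay: the limit of > 100000 nM in this assay, at which 1 of the 4 values shown sits.

As far as these compounds go, it remains open whether the step comes from gaining the hydroxyl or from losing the two fluorines. From the compounds shown here alone, how an amine or a carboxylic acid in place of the hydroxyl would read is also open.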